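The source may report more compounds than this note shows. Statements on the series, on what has been measured and on what is new or still open speak of the compounds shown alone.

Series notes, measured set in an ADME assay on HepG2 cells (Homo sapiens) for cytotoxicity, read by luminescence, CellTiter-Glo and ATP content, with a stated time of 72 h; on this read-out higher numbers stand for an effect only at larger amounts of compound and lower numbers for an effect already at smaller amounts:

- compound 1, `COc1ccc(Oc2ccc3c(NCCCNCc4cc(F)ccc4OC)ccnc3c2)cc1`: compound 1 gives 7000 nM
- compound 2, `CC(C)CCc1ccc2c(NCCCNCc3ccco3)ccnc2c1`: compound 2 gives 11200 nM
- compound 3, `COc1ccc(Oc2ccc3c(NCCCNCc4ccco4)ccnc3c2)cc1`: compound 3 gives 5300 nM

Compound 1 holds the second highest of the three numbers; its nearest neighbour is compound 3, the step being a 1.3-fold lower number from compound 1 to compound 3 (0.12 log units; within the scatter), and its furthest is compound 2, whose value lies within the scatter of that of compound 1.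

The unmeasured compound 4, `COc1ccc(F)cc1CNCCCNc1ccnc2cc(Cc3ccccc3)ccc12`, differs from compound 1 in one place: benzyl in place of 4-methoxyphenoxy on an aromatic carbon

Going by the values given here, only one measured step touches the same aromatic carbon, a 2.1-fold lower number from compound 2 to compound 3 (0.32 log units; beyond the scatter), in which a hydrocarbon substituent gave way to 4-methoxyphenoxy and the number fell modestly. The step from compound 1 to compound 4 runs the other way, 4-methoxyphenoxy giving way to a hydrocarbon substituent, benzyl, so a modest rise of the number in this assay is expected, near the edge of the scatter. Among the compounds with values here, no measured step shows benzyl itself, so the expectation rests on that single analogy.

For compound 4 the estimate in this assay is 10000 nM, with a range from 5000 nM to 20000 nM, which is expected to correspond to a 1.4-fold higher number from compound 1 to compound 4 (0.15 log units; within the scatter).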

Compound 4, half-maximal effective concentration: 7990 nM
Estimate against measurement, compound 4: 1.3-fold (0.10 log units) above; low and high end bracket the measured number.
By their numbers in this assay, from the lowest: compounds 3, 1, 4 and 2 (each within the scatter of the next, the first and the last beyond it).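

In this assay the exchange at this aromatic carbon gives a 1.1-fold higher number from compound 1 to compound 4 (0.06 log units; within the scatter) so, with the 5-fluoro-2-methoxyphenyl chain end in place, benzyl and 4-methoxyphenoxy cannot be told apart here. Going by these compounds alone, the only earlier step at this carbon, a 2.1-fold lower number from compound 2 to compound 3 (0.32 log units; beyond the scatter) with the furan-2-yl chain end in place, had left open whether any hydrocarbon substituent would separate from 4-methoxyphenoxy; benzyl does not, even though the hydrogen-bond acceptors counted on 4-methoxyphenoxy are absent from it. No measurement available here explains this result.

Going by these compounds, whether benzyl stays within the scatter of 4-methoxyphenoxy with the furan-2-yl chain end remains open. Also open, on these data alone, is whether an amine or a carboxylic acid on this aromatic carbon would move the number beyond the scatter.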